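The source may hold more compounds than are shown below. What is called first, only, known or untested is meant among the compounds shown, and "the series" means these compounds.

Compound 1 `Nc1cc(N)c2nc(-c3ccccc3)c(Oc3ccc(Cl)c(Cl)c3)nc2c1`: 39800 nM
Compound 2 `CCOC(=O)[C@H](CCC(=O)O)NC(=O)c1ccc(CNc2nc3cc(N)cc(N)c3nc2-c2ccccc2)cc1`: < 100000 nM, a limit only

Among the compounds with values here, in a functional assay on KM12 cells (Homo sapiens) for inhibition, read by sulforhodamine B assay, with a stated time of 48 h (a lower number here means a stronger inhibitor of growth, a higher number a weaker inhibitor of growth), compound 1 gives 39800 nM, the only true number in this set. Compound 2 reaches only the limit of the measurement, (the limit of < 100000 nM in this assay, at which 1 of the 2 values shown sits), so compound 1 stands alone as the measured point of reference. Compound 3 `COc1ccc(Sc2nc3cc(N)cc(N)c3nc2-c2ccccc2)cc1` differs from compound 1 by (4-methoxyphenyl)sulfanyl in place of 3,4-dichlorophenoxy on an aromatic carbon. Within the data shown here, no step between measured compounds is known here, so the size of the change cannot be read from the data; the step from compound 1 to compound 3 is expected to be a 1.0-fold higher number from compound 1 to compound 3 (0.00 log units; within the scatter), none beyond the usual scatter. Compound 3 is therefore estimated at 40000 nM, with a range from 10000 nM to 160000 nM.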

Compound 3, concentration for total growth inhibition: < 100000 nM
Compound 3: only a limit was reported; the forecaster's own chance of this, stated with the estimate: 30%; the middle value is on the limit's open side.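

Compound 3 gives only a limit, so no step between compound 1 and compound 3 can be read: the limit of < 100000 nM in this assay, at which 2 of the 3 values shown sit.

As far as these compounds go, whether (4-methoxyphenyl)sulfanyl in place of 3,4-dichlorophenoxy makes compound 3 a stronger or weaker inhibitor of growth than compound 1 stays open.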